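Swapping the hydroxy-bearing group of compound 2

The source may report more compounds than this note shows. Statements on the series, on what has been measured and on what is new or still open speak of the compounds shown alone.

Measured so far in a functional assay on KB cells (Homo sapiens) for antiproliferative activity, read by sulforhodamine B assay, with a stated time of 3 days; a lower number here means that less compound is needed, a higher number that more compound is needed for the effect:
- compound 1 `CCC1=C(O)c2c(oc(-c3ccc(C(C)C)cc3)cc2=O)C(CC)(CC)C1=O`: 8.13 uM
- compound 2 `CCC1=C(O)c2c(oc(-c3cc(C)c(O)c(C)c3)cc2=O)C(CC)(CC)C1=O`: 18.3 uM

Of these two, compound 2 has the higher number, at 18.3 uM. The unmeasured compound 3 `CCC1=C(O)c2c(oc(-c3ccc(F)c(C)c3)cc2=O)C(CC)(CC)C1=O` keeps the shared core but carries 4-fluoro-3-methylphenyl in place of 4-hydroxy-3,5-dimethylphenyl on an aromatic carbon. For the measured compounds named here, one measured step bears on this change: a 2.3-fold higher number from compound 1 to compound 2 (0.35 log units; beyond the scatter). That modest step came with 4-hydroxy-3,5-dimethylphenyl replacing 4-isopropylphenyl. The entering group has no hydroxy group, and neither has compound 1 at 8.13 uM, so a modest fall of similar size is expected, though a single pair sets no rule. The expected step is a 1.8-fold lower number from compound 2 to compound 3 (0.26 log units; within the scatter). The estimated value for compound 3 is 10 uM, with an expected range of 4.5 uM to 22 uM.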

Compound 3, concentration for half-maximal effect: 40.5 uM
Beside the measured number, compound 3's estimate is 4.1-fold (0.61 log units) below it; measured number outside the range, above it.
By their numbers in this assay, from the lowest: compound 1; then compound 2; then compound 3.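

In this assay the change to 4-fluoro-3-methylphenyl raised the number, with a 2.2-fold higher number from compound 2 to compound 3 (0.35 log units; beyond the scatter) even though the entering group has no hydroxy group. Compared with the 4-isopropylphenyl group, the same group gives a 5.0-fold higher number from compound 1 to compound 3 (0.70 log units; beyond the scatter) and so the two groups without a hydroxy group now stand at opposite ends of the three numbers, with hydroxy-bearing compound 2 in the middle, which shows that the absence of a hydroxy group does not by itself bring a low number at this position. Nothing available explains why the number rose.

From the compounds shown here alone, it remains open whether the fluoro or the methyl group accounts for the rise in compound 3. Also open, going by these compounds, is how an amine, a carboxylic acid or a longer chain on this phenyl ring would behave.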